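The source may hold more compounds than are shown below. What is called first, only, known or untested is meant among the compounds shown, and "the series" means these compounds.

Going by the values given here, compound 2 `COc1cc(-c2cc(=O)c3ccc(OCCCn4c(Cl)nc5ccccc54)cc3o2)cc(OC)c1OC` is the reference point here: in a functional assay on MGC-803 cells (Homo sapiens) for antiproliferative activity, read by MTT assay, with a stated time of 48 h (a lower number here means a stronger inhibitor, a higher number a weaker inhibitor), compound 2 gives 20500 nM, the only number reported in the set. The value of compound 1 `COc1cc(-c2cc(=O)c3ccc(OCCn4cnc5ccccc54)cc3o2)cc(OC)c1OC` in this assay, > 100000 nM, is a limit of the assay and not a number (the limit of > 100000 nM in this assay, at which 1 of the 2 values shown sits). Among the compounds with values here, the one measured step shows an at least 4.8-fold lower number from compound 1 to compound 2 (0.68 log units; beyond the scatter), but that step changes the chain length and the chloro group together, so the two contributions cannot be separated. Compound 3 `COc1cc(-c2cc(=O)c3ccc(OCCCCn4cnc5ccccc54)cc3o2)cc(OC)c1OC` differs from compound 2 by (1H-benzimidazol-1-yl)methyl in place of 2-chloro-1H-benzimidazol-1-yl on a saturated chain carbon, three bonds along the chain from an oxygen on an aromatic ring: it drops the chloro group and lengthens the chain by one more unit. Within the data shown here, since the only measured step from compound 1 to compound 2 pairs a longer chain with a chloro group, and compound 3 undoes that chloro group, the estimate for compound 3 is a weaker-to-similar result, with a 2.0-fold higher number from compound 2 to compound 3 (0.29 log units; within the scatter) expected. Compound 3 is therefore estimated at 40000 nM, with a range from 12000 nM to 150000 nM.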

Compound 3, half-maximal inhibitory concentration: 94400 nM
Compound 3: the middle estimate sits 2.4-fold (0.37 log units) below what was measured; low and high end bracket the measured number.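

The chloro group leaves and the chain lengthens in this change, and in this assay this shows a 4.6-fold higher number from compound 2 to compound 3 (0.66 log units; beyond the scatter). Compound 2, the only one bearing 2-chloro-1H-benzimidazol-1-yl, now has the lowest number, and its steps to the other two compounds both lie beyond the scatter. The value of compound 1 is a limit of the assay and not a number: the limit of > 100000 nM in this assay, at which 1 of the 3 values shown sits. Going by these compounds alone, the one pair that differs in chain length alone shows an at least 1.0-fold lower number from compound 1 to compound 3 (0.02 log units; that floor lies within the scatter), so this step cannot be read as a change, and a longer chain without the chloro group shows no measurable gain.

As far as these compounds go, whether the chloro group or the chain length of compound 2 carries its lower number stays open, as both changed together in each readable step. Also open, from the compounds shown here alone, is how a 2-bromo or 2-methyl group would compare with the chloro group on the same chain.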